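Three limits, one new aryl group: what to expect

The compounds below may be only part of what the source reports. "The series", "measured", "known", "first", "only" and "open" are said of these compounds alone.

Compound 1 `O=C(NCCO)c1c(Cn2c(=O)n(C3CC3)c3ccncc32)nc2cc(Cl)ccn12` gives > 100000 nM in an ADME assay on HEp-2 cells (Homo sapiens) for cytotoxicity, read by CCK-8 assay, with a stated time of 6 days (a higher number here means that more compound is tolerated, a lower number that less compound is tolerated), a limit of that assay.
Compound 2 `O=C(O)/C=C/c1c(Cn2c(=O)n(C3CC3)c3ccncc32)nc2cc(Cl)ccn12` gives > 100000 nM in this assay, again a limit.
Compound 3 `O=C(CCc1c(Cn2c(=O)n(C3CC3)c3ccncc32)nc2cc(Cl)ccn12)NCCO` gives > 100000 nM in this assay, again a limit.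

Compound 3 therefore stands at the limit of this assay, not at a number, and the two other values shown stand at the same limit (the limit of > 100000 nM in this assay, at which 3 of the 3 values shown sit). The steps among the measured compounds, a step that the two limits leave unreadable from compound 1 to compound 2, a step that the two limits leave unreadable from compound 1 to compound 3 and a step that the two limits leave unreadable from compound 2 to compound 3, cannot be read for size, since both ends of each sit at that limit.

Compound 4 `CS(=O)(=O)c1ccc(-c2c(Cn3c(=O)n(C4CC4)c4ccncc43)nc3cc(Cl)ccn23)cc1` is not yet measured. It differs from compound 3 in one place: 4-(methylsulfonyl)phenyl in place of 2-((2-hydroxyethyl)carbamoyl)ethyl on an aromatic carbon. Within the data shown here, none of the measured steps gives a readable size, so no direction or size of step in this assay can be drawn from them; the only thing the data show is that every compound of this series so far has exceeded the limit.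

On that basis compound 4 is expected to sit at about 100000 nM in this assay, in the range 30000 nM to 300000 nM, most likely again as a limit. The step this estimate means, a number no higher from compound 3 to compound 4 (the limit leaves the size open), is expected to be none beyond the scatter.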

Compound 4, half-maximal cytotoxic concentration: > 100000 nM
Compound 4 gave a limit, no number; the forecaster's own chance of this, stated with the estimate: 65%; the middle value lies on the limit itself.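

In this assay compound 4 gives > 100000 nM as a limit. Its steps from compound 1, compound 2 and compound 3 cannot be read for size, since all sit at one limit: the limit of > 100000 nM in this assay, at which 4 of the 4 values shown sit. The compounds shown leave open at what concentration any of them becomes cytotoxic to these cells.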